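The source may hold more compounds than are shown below. What is called first, only, known or untested is meant among the compounds shown, and "the series" means these compounds.

Compound 1 `Nc1nc(-c2cnco2)nc2sc(Cc3ccccc3)cc12`: 106 nM
Compound 2 `Cc1csc(-c2nc(N)c3cc(Cc4ccccc4F)sc3n2)n1`: 28.6 nM
Compound 3 `C=C(c1ccccc1)c1cc2c(N)nc(-c3cccc(C#N)c3)nc2s1`: > 1000 nM

Of the compounds shown here, three built on the same fused core have been tested in a functional assay on CHO-K1 cells for antagonist activity at adenosine receptor A1 (Homo sapiens), read by a beta-galactosidase reporter and cAMP accumulation, with stated times of 15 min and 6 h; on this read-out lower numbers stand for stronger inhibition and higher numbers for weaker inhibition. Compound 1 gives 106 nM, which is the higher of the two plain numbers recorded. Compound 2 gives 28.6 nM, a lower number than compound 1, and the gap between the two lies beyond the scatter of repeated runs. For compound 3 the recorded value > 1000 nM is a limit of the assay rather than a number, (the limit of > 1000 nM in this assay, at which 1 of the 3 values shown sits).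

The step followed here leads from compound 1 to compound 4 `Nc1nc(-c2cccc(Cl)n2)nc2sc(Cc3ccccc3)cc12`, which has not yet been measured. The change is 6-chloropyridin-2-yl in place of 1,3-oxazol-5-yl on an aromatic carbon. Among the compounds with values here, no measured pair differs in just this one place, so the expectation rests only on compounds 1, 2 and 3 and on the change itself. The step is expected to be small, a 1.4-fold higher number from compound 1 to compound 4 (0.15 log units; within the scatter), leaning toward weaker inhibition but not clearly beyond the usual scatter. For compound 4 the estimated value in this assay is 150 nM, with a likely range from 40 nM to 600 nM.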

Compound 4, inhibition constant: > 1000 nM
Compound 4 gave a limit, no number (the forecaster's own chance of this, stated with the estimate: 15%); middle value at least 6.6-fold (0.82 log units) away from the limit.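

Within the data shown here, compound 4 and compound 1 form the first pair here that differs in just one place, so the group on the aromatic carbon between two ring nitrogen atoms can now be judged on its own. In this assay, 6-chloropyridin-2-yl in place of 1,3-oxazol-5-yl gives an at least 9.4-fold higher number from compound 1 to compound 4 (0.97 log units; beyond the scatter), so this position does not accept every aromatic ring equally. Compound 4 gives > 1000 nM, which is a limit of the assay and not a number, and the full size of the step stays unknown because the reading stops at that limit: the limit of > 1000 nM in this assay, at which 2 of the 4 values shown sit.

As far as these compounds go, what stays open is whether the chlorine or the six-membered ring accounts for the weaker inhibition. A plain pyridin-2-yl at this position would separate the two, and a methoxy group in place of the chlorine would show whether another substituent there behaves the same way.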